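The compounds below may be only part of what the source reports. "The series", "measured", "known", "first", "only" and "open" are said of these compounds alone.

Among the measured compounds shown here, compound 3 `CC(=O)N1CCC[C@H](NS(=O)(=O)C(C)C)[C@@H]1CO[C@H]1CC[C@@H](C(C)C)CC1` is the one compound of the three measured that gives a number: in a functional assay on CHO-K1 cells for agonist activity at Orexin receptor type 2 (Homo sapiens), read by FLIPR and calcium flux (on this read-out higher numbers stand for an effect only at larger amounts of compound and lower numbers for an effect already at smaller amounts), compound 3 gives 940 nM. Compound 1 `CCS(=O)(=O)N[C@@H]1CCCN(C(C)=O)[C@H]1CO[C@H]1CC[C@@H](C(C)C)CC1` reaches only a limit of this assay, at > 30000 nM. Compound 2 `CCS(=O)(=O)N[C@@H]1CCCN(C(C)=O)[C@H]1CO[C@H]1CC[C@H](C(C)C)CC1` likewise stops at a limit, > 30000 nM. The step that the two limits leave unreadable from compound 1 to compound 2 cannot be read because of the limit of > 30000 nM in this assay, at which 2 of the 3 values shown sit, and the two compounds differ only as described by the fact that compounds 1 and 2 differ only in the configuration as drawn. Compound 4 `CC(=O)N1CCC[C@H](NC(=O)O)[C@@H]1CO[C@H]1CC[C@@H](C(C)C)CC1` carries the change (carboxy in place of isopropylsulfonyl on an amine nitrogen). For the measured compounds named here, no measured step touches this change, so the size of the step is open. The step of an 11-fold higher number from compound 3 to compound 4 (1.03 log units; beyond the scatter) is expected to run toward larger amounts of compound. Compound 4 is therefore estimated at 10000 nM, between 2000 nM and 30000 nM.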

Compound 4, half-maximal effective concentration: > 30000 nM
Compound 4 gave a limit, no number; the forecaster's own chance of this, stated with the estimate: 45%; at least 3.0-fold (0.47 log units) between middle value and limit.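

On an amine nitrogen of the shared core, carboxy in place of isopropylsulfonyl brings an at least 31-fold higher number from compound 3 to compound 4 (1.50 log units; beyond the scatter) in this assay. Among the compounds shown here, this is the first measured change at this place, and it shows that the group there can decide whether the assay returns a number at all. The step is only a minimum because one end of it is a limit and not a number: the limit of > 30000 nM in this assay, at which 3 of the 4 values shown sit.

From the compounds shown here alone, the true size of the step stays open. So does how cyclopropylsulfonyl or acetyl on this amine nitrogen would read.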